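Swapping the Sulfonyl Aryl Group Back Toward a Halophenyl

The source may report more compounds than this note shows. Statements on the series, on what has been measured and on what is new or still open speak of the compounds shown alone.

Measured compounds:
compound 1, `O=C(NCc1ccc(CNS(=O)(=O)c2ccc(Cl)cc2)cc1)c1ccc(CNc2ncccn2)cc1`, 100 nM
compound 2, `O=C(NCc1ccc(CNS(=O)(=O)c2ccc3c(c2)CCO3)cc1)c1ccc(CNc2ncccn2)cc1`, 1000 nM

The two measured compounds share one core and differ only in the group on the sulfonyl sulfur. In an assay on MDA-MB-231 cells for binding affinity to C-X-C chemokine receptor type 4 (Homo sapiens), read by microscopy, with stated times of 10 min and 30 min (a higher number here means that more compound is needed for the effect, a lower number that less compound is needed), compound 1 gives 100 nM, and in this assay compound 2 gives 1000 nM. For the measured compounds named here, the single measured step is a 10-fold higher number from compound 1 to compound 2 (1.00 log units; beyond the scatter). Compound 2 therefore stands with the highest number of the two shown, its only neighbour being compound 1, which sits a full step below it.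

Compound 3, `O=C(NCc1ccc(CNS(=O)(=O)c2cccc(F)c2)cc1)c1ccc(CNc2ncccn2)cc1`, is not yet measured. It differs from compound 2 in this way: a group of 7 heavy atoms (6 carbon, 1 fluorine; one six-membered aromatic ring of carbon only) in place of a group of 9 heavy atoms (8 carbon, 1 oxygen; one five-membered non-aromatic ring with 1 hetero atom, one six-membered aromatic ring of carbon only), on a sulfonyl sulfur.

The step from compound 1 to compound 2 bears directly on this change, since it also exchanged a seven-heavy-atom halophenyl for the nine-heavy-atom group, and it moved the number up beyond the scatter. Going the other way, from the nine-heavy-atom group back to a halophenyl, the account expects a step down in this assay of roughly comparable size, though the entering 3-fluorophenyl is not the same group as the one in compound 1, so the expected size is set somewhat smaller. The expected step is a 5.0-fold lower number from compound 2 to compound 3 (0.70 log units; beyond the scatter). The estimate for compound 3 in this assay is therefore 200 nM, with a range from 60 nM to 700 nM.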

Compound 3, effective concentration (reported as EC, without a stated level of effect): 1000 nM
The estimate for compound 3 lay 5.0-fold (0.70 log units) below the measured number; measured number above the stated range.
By their numbers in this assay, from the lowest: compound 1; then compounds 2 and 3 (each within the scatter of the next).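

In this assay, putting 3-fluorophenyl on the sulfonyl sulfur in place of the nine-heavy-atom group gives no change at the digits printed from compound 2 to compound 3 (within the scatter), which shows that a halophenyl at this position does not by itself bring the number down. The exchange of 4-chlorophenyl for 3-fluorophenyl gives a 10-fold higher number from compound 1 to compound 3 (1.00 log units; beyond the scatter), so the two halophenyl groups are separated beyond the scatter, and of the three groups shown only the 4-chlorophenyl of compound 1 holds the lower number. Nothing available explains why these two halophenyl groups part in this way.

Because 3-fluorophenyl and 4-chlorophenyl differ in both the halogen and its location on the ring, the compounds shown cannot say which of the two differences carries the step, a question that 3-chlorophenyl and 4-fluorophenyl would separate. They also leave open how an unsubstituted phenyl or a 4-bromophenyl on the sulfonyl sulfur would stand in this assay, and so whether any halogen is needed at this position at all.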